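A few compounds are considered here, and "the series" means these few. Any claim that something is new, unique, unknown or untested is made for them only; others in the source may bear on it.

In a functional assay on SGC-7901 cells (Homo sapiens) for antiproliferative activity, read by MTT assay, with a stated time of 72 h (on this read-out lower numbers stand for stronger inhibition and higher numbers for weaker inhibition), compound 1 `CCOC(=O)c1cc(-c2ccc(OC)cc2)c(-c2cc(OC)c(OC)c(OC)c2)s1` gives 6820 nM, and compound 2 `CCOC(=O)c1cc(-c2ccc(OC)c([N+](=O)[O-])c2)c(-c2cc(OC)c(OC)c(OC)c2)s1` gives 19400 nM. Compound 3 `CCOC(=O)c1cc(-c2ccc(OC)c(OCc3ccccc3)c2)c(-c2cc(OC)c(OC)c(OC)c2)s1` gives only > 100000 nM, which is a limit of the assay and not a number. Compound 4 `CCOC(=O)c1cc(-c2ccc(OC)c(O)c2)c(-c2cc(OC)c(OC)c(OC)c2)s1` differs from it by hydrogen in place of benzyl on an oxygen on an aromatic ring, or benzyloxy to hydroxy. Among the compounds with values here, no measured step has a hydroxy group on either side, so the expectation rests on the benzyloxy steps. These are an at least 14-fold higher number from compound 1 to compound 3 (1.16 log units; beyond the scatter) and an at least 5.1-fold higher number from compound 2 to compound 3 (0.71 log units; beyond the scatter), and both end at the limit. The nitro step, a 2.8-fold higher number from compound 1 to compound 2 (0.45 log units; beyond the scatter), is smaller. Taking the benzyl group away is therefore expected to bring a large step towards a lower number in this assay, back to the level of compound 1 at 6820 nM. For compound 4 the estimated value is 7000 nM, with an expected range from 1500 nM to 30000 nM. This estimate amounts to an expected at least 14-fold lower number from compound 3 to compound 4 (1.15 log units; beyond the scatter).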

Compound 4, half-maximal inhibitory concentration: 20000 nM
The estimate for compound 4 lay 2.9-fold (0.46 log units) below the measured number; the measured number falls inside the stated range.
By their numbers in this assay, from the lowest: compound 1; then compounds 2 and 4 (each within the scatter of the next). At a limit, above all of these: compound 3.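

In this assay, hydrogen in place of benzyl on an oxygen on an aromatic ring brings the series back to a measurable number, an at least 5.0-fold lower number from compound 3 to compound 4 (0.69 log units; beyond the scatter), but the hydroxy group does not return to the level of hydrogen on that carbon, a 2.9-fold higher number from compound 1 to compound 4 (0.47 log units; beyond the scatter). Hydroxy and nitro on this carbon give matching numbers, a 1.0-fold higher number from compound 2 to compound 4 (0.01 log units; within the scatter), so all three groups shown there stand above hydrogen, with no exception among these compounds. Compound 3 gives a limit of the assay and not a number, so its step is only a bound: the limit of > 100000 nM in this assay, at which 1 of the 4 values shown sits.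

On these data alone, whether a small ether such as ethoxy, or a longer alkyl chain on the same oxygen, stays near hydroxy or moves towards benzyloxy remains open. So does the outcome for an amine or a carboxylic acid on this carbon.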